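Anilino in place of 4-hydroxyphenyl on compound 2

This account rests on a few compounds, and the source may have more. Where it says the series, first, only, none or still open, it means among the compounds named here.

The series holds three measured compounds: compound 1 `O=c1cc(/C=N\c2ccccc2O)c2c(OCc3ccccc3)cc(OCc3ccccc3)cc2o1`, compound 2 `O=c1cc(/C=N\c2ccc(O)cc2)c2ccc(OCc3ccccc3)cc2o1` and compound 3 `O=c1cc(/C=N\Nc2ccc([N+](=O)[O-])cc2[N+](=O)[O-])c2ccc(OCc3ccccc3)cc2o1`. In a functional assay, read by spectrophotometry, with a stated time of 5 min (on this read-out higher numbers stand for weaker inhibition and lower numbers for stronger inhibition), compound 2 gives 525000 nM, the highest of the three numbers. Compound 3 is nearest at 181000 nM, and compound 1 is furthest at 33100 nM. Both gaps lie beyond the scatter.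

The next compound is compound 4 `O=c1cc(/C=N\Nc2ccccc2)c2ccc(OCc3ccccc3)cc2o1`, which has anilino in place of 4-hydroxyphenyl on a double-bonded nitrogen.

Within the data shown here, no pair of measured compounds differs in one place only, so this change has no direct precedent and any expectation is loose. The closest guide is compound 3 at 181000 nM, which also has a substituted anilino group on the double-bonded nitrogen and the same benzyloxy pattern as compound 4. It still differs from compound 4 in the substituents on that ring. On that single comparison, the number in this assay is expected to fall by a moderate amount, and the expected step is a 2.6-fold lower number from compound 2 to compound 4 (0.42 log units; beyond the scatter). With so little support, a step within the scatter cannot be excluded.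

For compound 4 the estimated value is 200000 nM, with an expected range of 70000 nM to 550000 nM.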

Compound 4, half-maximal inhibitory concentration: 416000 nM
For compound 4 the middle estimate is 2.1-fold (0.32 log units) below the measured one; measured number inside the range.
By their numbers in this assay, from the lowest: compound 1; then compound 3; then compounds 4 and 2 (each within the scatter of the next).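

In this assay, the series now has its first comparison that differs in one place, and it reads a 1.3-fold lower number from compound 2 to compound 4 (0.10 log units; within the scatter), so anilino in place of 4-hydroxyphenyl on a double-bonded nitrogen does not separate the two compounds. The two groups have equal counts of heavy atoms, hydrogen-bond donors and hydrogen-bond acceptors, and each carries one six-membered aromatic ring of carbon only, so at this position the exchange of oxygen for nitrogen between the groups leaves the read-out unresolved from the usual scatter. No measurement on hand bears on why the two groups read alike.

Among these compounds, this single pair cannot show whether the position tolerates change in general or only this exchange, and compound 1 and compound 3 each differ from the pair in more than one place, so they add no direct reading. Still open, from the compounds shown here alone, is what happens at the double-bonded nitrogen with a group of another kind, such as a carboxylic acid on the anilino ring or a plain methyl in place of the whole aromatic ring.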